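Acyl exchange on compound 3: expected cytotoxicity

This account rests on a few compounds, and the source may have more. Where it says the series, first, only, none or still open, it means among the compounds named here.

In a functional assay on MCF7 cells (Homo sapiens) for cytotoxicity, read by MTT assay, with a stated time of 48 h (on this read-out higher numbers stand for weaker inhibition and lower numbers for stronger inhibition), compound 1 `CCCCCCCCNC(=O)[C@@H](NC(=O)c1ccco1)[C@@H](C)O` gives 91800 nM, compound 2 `CCCCCCCCNC(=O)[C@@H](NC(=O)c1cccs1)[C@@H](C)O` gives 72500 nM and compound 3 `CCCCCCCCCCCCNC(=O)[C@@H](NC(=O)c1cccs1)[C@@H](C)O` gives 30400 nM. The acyl exchange a 1.3-fold lower number from compound 1 to compound 2 (0.10 log units; within the scatter) changes little. The chain extension a 2.4-fold lower number from compound 2 to compound 3 (0.38 log units; beyond the scatter) lowers the number. Compound 3 therefore stands at the lowest of the three numbers, beyond the scatter from compound 2 and from compound 1.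

Compound 4 `CCCCCCCCCCCCNC(=O)[C@@H](NC(=O)/C=C/c1ccccc1)[C@@H](C)O` keeps the long chain of compound 3 and differs only at the acyl group: 2-phenylethenyl in place of thiophen-2-yl on a carbonyl carbon. Of the measured steps, only the acyl exchange from compound 1 to compound 2 bears on this change, and that step stayed within the scatter. Within the data shown here, the entering 2-phenylethenyl group has no measured counterpart, so its effect on this assay is not anchored by any step. With no measured acyl change moving the read-out beyond the scatter, a small step is expected: for compound 4 the step expected in this assay is a 1.2-fold lower number from compound 3 to compound 4 (0.08 log units; within the scatter), essentially none beyond the scatter, with a wide range to cover the unanchored group. The estimate for compound 4 in this assay is 25000 nM, expected to fall between 8000 nM and 80000 nM.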

Compound 4, half-maximal inhibitory concentration: > 200000 nM
Compound 4: only a limit was reported (the forecaster's own chance of this, stated with the estimate: 10%); at least 8.0-fold (0.90 log units) between middle value and limit.
By their numbers in this assay, from the lowest: compound 3; then compounds 2 and 1 (each within the scatter of the next). At a limit, above all of these: compound 4.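

In this assay the acyl group on the carbonyl carbon is not a neutral place in the series: the exchange that stayed small as a 1.3-fold lower number from compound 1 to compound 2 (0.10 log units; within the scatter) has a much larger counterpart in an at least 6.5-fold higher number from compound 3 to compound 4 (0.81 log units; beyond the scatter). Compound 4 gives > 200000 nM, a limit of the assay and not a number, and the step rests on that limit: the limit of > 200000 nM in this assay, at which 1 of the 4 values shown sits. The long chain shared by compound 3 and compound 4 therefore does not hold the read-out low by itself, and the gain seen with a 2.4-fold lower number from compound 2 to compound 3 (0.38 log units; beyond the scatter) holds here only with thiophen-2-yl as the acyl group.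

The compounds shown do not separate the double bond from the six-membered aromatic ring of the entering group; a benzoyl group or a saturated 2-phenylethyl group on the same carbonyl carbon would address that. From the compounds shown here alone, how 2-phenylethenyl reads on the shorter chain of compound 2 also remains open, as does whether a chain longer than that of compound 3 would move the read-out further.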